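Thioether heteroaryl swap on the hydroxycoumarin series

The source may hold more compounds than are shown below. What is called first, only, known or untested is meant among the compounds shown, and "the series" means these compounds.

Two compounds of this series have numbers in an assay on HeLa cells for inhibition of 17-beta-hydroxysteroid dehydrogenase type 3 (Homo sapiens); a higher number here means a weaker inhibitor, a lower number a stronger inhibitor. Compound 1 `O=c1cc(COc2ccccc2)c2ccc(O)cc2o1` gives 10000 nM. Compound 2 `O=c1cc(CSc2ccncc2)c2ccc(O)cc2o1` gives 5000 nM. Compound 2 has the lowest of the two numbers; its nearest neighbour is compound 1, and the gap between them lies within the scatter, so the two read as equivalent. Compound 3 `Cn1ccnc1SCc1cc(=O)oc2cc(O)ccc12` has not yet been measured in this assay . It differs from compound 2 in one place: 1-methyl-1H-imidazol-2-yl in place of pyridin-4-yl on a sulfur. Within the data shown here, no measured pair shows what such a change does, so the step has to be guessed. Compound 3 is expected to sit close to compound 2, with the step from compound 2 to compound 3 estimated at no change at the digits printed from compound 2 to compound 3 (within the scatter), no larger than the scatter in either direction. Compound 3 is therefore estimated at 5000 nM, in a range from 1500 nM to 16000 nM.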

Compound 3, half-maximal inhibitory concentration: 91 nM
Compound 3: middle estimate off by 55-fold (1.74 log units), on the high side; the whole stated range lies above it.
By their numbers in this assay, from the lowest: compound 3; then compounds 2 and 1 (each within the scatter of the next).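

In this assay, 1-methyl-1H-imidazol-2-yl in place of pyridin-4-yl on a sulfur gives a 55-fold lower number from compound 2 to compound 3 (1.74 log units; beyond the scatter), so the aromatic ring on this sulfur can move the number well beyond the scatter. The two rings carry the same count of heavy atoms, so that count alone does not set the number here; they differ in ring size and in hetero atoms. No measurement shown accounts for the size of this step.

The change alters ring size, hetero atom count and the methyl group at once, and the compounds shown do not separate these. Open, from the compounds shown here alone, are the same imidazole ring without its methyl group, 1-methyl-1H-imidazol-2-yl attached through an oxygen in place of the sulfur, and a longer chain in place of the saturated chain carbon.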